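Swapping bromo for nitro at the assay limit

This account rests on a few compounds, and the source may have more. Where it says the series, first, only, none or still open, it means among the compounds named here.

Compound 1 `COc1cc(/C(=C/c2ccc(C)cc2)C(C)O)cc(OC)c1OC` gives > 100000 nM
Compound 2 `COc1cc(/C(=C/c2ccc(Br)cc2)C(C)O)cc(OC)c1OC` gives > 100000 nM

In a functional assay on B16 cells (Mus musculus) for antiproliferative activity, read by MTT assay, with a stated time of 72 h (on this read-out higher numbers stand for weaker inhibition and lower numbers for stronger inhibition), compound 1 gives > 100000 nM, which is a limit of the assay and not a number. Compound 2 gives > 100000 nM in this assay, and this too is a limit. Compound 2 therefore has no exact place on the scale, and the whole picture so far is the limit of > 100000 nM in this assay, at which 2 of the 2 values shown sit.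

Compound 3 `COc1cc(/C(=C/c2ccc([N+](=O)[O-])cc2)C(C)O)cc(OC)c1OC` keeps the shared core and changes one group: nitro in place of bromo on an aromatic carbon. Nitro replaces bromo on an aromatic carbon, para to a large group.

Among the compounds with values here, the one measured step that bears on this is a step that the two limits leave unreadable from compound 1 to compound 2. With no readable size, it offers no number to carry over. The starting point, compound 2 with > 100000 nM, is also only a limit, so no step beyond the scatter is expected in this assay. The expected step is a number no higher from compound 2 to compound 3 (the limit leaves the size open). Compound 3 may well be reported only as a limit again. For compound 3 the estimated value is 100000 nM, with an expected range from 30000 nM to 300000 nM.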

Compound 3, half-maximal inhibitory concentration: > 100000 nM
Compound 3: a limit, no number (the forecaster's own chance of this, stated with the estimate: 75%); the middle value lies on the limit itself.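

In this assay compound 3 gives > 100000 nM, which is a limit and not a number. No new step can be read between compound 3 and either compound 1 or compound 2, and the picture stays as it was: the limit of > 100000 nM in this assay, at which 3 of the 3 values shown sit. The compounds shown leave open whether methyl, bromo and nitro differ at all in their effect on these cells.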